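A few compounds are considered here, and "the series" means these few. Any claim that something is new, unique, unknown or untested is made for them only; others in the source may bear on it.

Of the compounds shown here, three have been measured. In an assay for inhibition of HSP60/HSP10 (Homo sapiens), with a stated time of 60 min (a lower number here means a stronger inhibitor, a higher number a weaker inhibitor), compound 2 `O=C(Nc1ccc(Sc2nc3ccccc3s2)c(Cl)c1)c1cc(Br)cc(Br)c1O` gives 4200 nM. Compound 3 `O=C(Nc1ccc(Sc2nc3ccccc3s2)cc1)c1cc(Br)cc(Br)c1O` gives 4700 nM in this assay. For compound 1 `O=C(Nc1ccc(Sc2nc3ccccc3s2)c(Cl)c1)c1cccc(Br)c1` only a limit of this assay is reported, > 100000 nM, the value sitting at the limit of > 100000 nM in this assay, at which 1 of the 3 values shown sits.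

Compound 2 and compound 3 share all but one feature, and the step of a 1.1-fold higher number from compound 2 to compound 3 (0.05 log units; within the scatter). Compound 1 carries 3-bromophenyl in place of 3,5-dibromo-2-hydroxyphenyl on a carbonyl carbon, and here the step of an at least 23-fold higher number from compound 2 to compound 1 (1.37 log units; beyond the scatter), its end point being a limit.

Compound 4 `O=C(Nc1ccc(Sc2nc3ccccc3s2)cc1)c1cccc(Br)c1` has not been measured. It differs from compound 3 by 3-bromophenyl in place of 3,5-dibromo-2-hydroxyphenyl on a carbonyl carbon, the same change as from compound 2 to compound 1, since both place descriptions read identically. The two cores differ by hydrogen in place of chloro on an aromatic carbon. Compound 4 is expected to show a step of comparable size, a 21-fold higher number from compound 3 to compound 4 (1.33 log units; beyond the scatter), resting on an at least 23-fold higher number from compound 2 to compound 1 (1.37 log units; beyond the scatter) for compound 1. Compound 4 is thus estimated at 100000 nM, between 30000 nM and 300000 nM, most likely again as a limit.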

Compound 4, half-maximal inhibitory concentration: > 100000 nM
Compound 4 gave a limit, no number; the forecaster's own chance of this, stated with the estimate: 75%; the middle value lies on the limit itself.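

In this assay, 3-bromophenyl in place of 3,5-dibromo-2-hydroxyphenyl on a carbonyl carbon gives a large step on the second core as well, an at least 21-fold higher number from compound 3 to compound 4 (1.32 log units; beyond the scatter), so the loss seen on the core of compound 2 carries over to the core of compound 3: the same change on two cores in this assay, an at least 23-fold higher number (1.37 log units; beyond the scatter) from compound 2 to compound 1 and an at least 21-fold higher number (1.32 log units; beyond the scatter) from compound 3 to compound 4; the limit leaves it open whether they differ. Compound 4 gives > 100000 nM, which is a limit of the assay and not a number. The result shows the direction of the change on both cores and not its true size on either, and the step between compound 1 and compound 4 cannot be read: the limit of > 100000 nM in this assay, at which 2 of the 4 values shown sit.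

In the compounds shown, the hydroxy group and one bromine leave together, so it stays open which of the two matters. Also open, from the compounds shown here alone, is whether an amine or a methoxy group in place of the hydroxy group would keep the value.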